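Adding a Methoxy Group to a Weak Antiproliferative Chalcone

This account rests on a few compounds, and the source may have more. Where it says the series, first, only, none or still open, it means among the compounds named here.

Measured compounds:
- Compound 1 `COc1cc(C(=O)/C=C/c2cc(-c3cc(OC)c(OC)c(OC)c3)n3nc(-c4ccccc4)cc3n2)cc(OC)c1OC`: 34900 nM
- Compound 2 `COc1ccc(-c2cc(/C=C/C(=O)c3ccc(C)cc3)nc3cc(-c4ccccc4)nn23)cc1OC`: 26800 nM

Both compounds were tested in a functional assay on DU-145 cells (Homo sapiens) for antiproliferative activity, read by MTT assay, with a stated time of 24 h; a higher number here means a weaker inhibitor, a lower number a stronger inhibitor. Compound 1 gives 34900 nM in this assay, and compound 2 gives 26800 nM. The two numbers sit within the usual scatter of each other, so neither compound can be called the stronger one on this evidence. Both are weak inhibitors of the cells.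

Compound 3 `COc1cc(-c2cc(/C=C/C(=O)c3ccc(C)cc3)nc3cc(-c4ccccc4)nn23)cc(OC)c1OC` has not yet been measured. It differs from compound 2 in one place: methoxy in place of hydrogen on an aromatic carbon. The change is small and adds one hydrogen-bond acceptor to the ring that already carries two methoxy groups.

Since compound 1, which also carries a trimethoxyphenyl group, gives 34900 nM, no step beyond the scatter is expected here. For compound 3 the expected step is a 1.0-fold higher number from compound 2 to compound 3 (0.00 log units; within the scatter), and its value is estimated at 27000 nM with a range from 11000 nM to 65000 nM.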

Compound 3, half-maximal inhibitory concentration: 27100 nM
For compound 3 the middle estimate is 1.0-fold (0.00 log units) below the measured one; the range from low to high includes it.
By their numbers in this assay, from the lowest: compounds 2, 3 and 1 (each within the scatter of the next).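

In this assay, replacing the 3,4-dimethoxyphenyl group of compound 2 with the 3,4,5-trimethoxyphenyl group of compound 3 gives no readable change (a 1.0-fold higher number from compound 2 to compound 3 (0.00 log units; within the scatter)), so this methoxy group, on this ring, makes no difference that the measurement can detect. Compound 3 also isolates a second place, the group on the carbonyl carbon, and putting 4-methylphenyl there in place of 3,4,5-trimethoxyphenyl likewise stays within the scatter (a 1.3-fold lower number from compound 1 to compound 3 (0.11 log units; within the scatter)). Nothing available explains why either change leaves the activity where it is.

The compounds shown leave open whether a different group on the same ring carbon, such as an amine or a carboxylic acid, would move the number beyond the scatter. They also leave open whether changing the shared core, rather than these outer rings, would give stronger inhibitors.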